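This account rests on a few compounds, and the source may have more. Where it says the series, first, only, none or still open, it means among the compounds named here.

Measured so far:
compound 1 `C/C=C/C(=O)Nc1c(C(O)(C(F)(F)F)C(F)(F)F)ccc2ccccc12` — 96%
compound 2 `O=C(Nc1c(C(O)(C(F)(F)F)C(F)(F)F)ccc2ccccc12)c1ccco1` — 96%

In a functional assay (Sus scrofa) with sulfonylurea receptors; K-ATP channels (Homo sapiens) as the target (a higher number here means a larger maximal response, a lower number a smaller maximal response), compound 2 gives 96%, level with compound 1, which gives 96%. Among the measured compounds shown here, the only measured step here, no change at the digits printed from compound 1 to compound 2 (within the scatter), shows that exchanging one five-membered heteroaryl for an alkenyl group on the carbonyl carbon left the response unchanged. Compound 3 `O=C(Nc1c(C(O)(C(F)(F)F)C(F)(F)F)ccc2ccccc12)c1cnco1` differs from compound 2 in the same position: 1,3-oxazol-5-yl in place of furan-2-yl on a carbonyl carbon. Since the step from compound 1 to compound 2 stayed within the scatter, compound 3 is expected to stay level as well, a number 1 percentage points lower from compound 2 to compound 3 (within the scatter). Compound 3 is therefore estimated at 95%, with a range from 82% to 105%.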

Compound 3, largest response reached (reported as efficacy), in percent of the reference or control that the assay uses: 97%
The estimate for compound 3 lay 2 percentage points below the measured number; the range from low to high includes it.
By their numbers in this assay, from the lowest: compounds 1, 2 and 3 (each within the scatter of the next).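

In this assay, a ring with a nitrogen and a second hydrogen-bond acceptor takes the place of furan-2-yl on the carbonyl carbon, and the maximal response gives a number 1 percentage points higher from compound 2 to compound 3 (within the scatter). Against the alkenyl group, 1,3-oxazol-5-yl gives a number 1 percentage points higher from compound 1 to compound 3 (within the scatter), so prop-1-en-1-yl and both five-membered aromatic rings all lie within the scatter of one another at this position. Nothing available accounts for this flat result. Still open, as far as these compounds go, is whether the response holds with an amine, a carboxylic acid or a longer alkyl chain on this carbonyl carbon.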